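Methoxy for fluoro, read on two cores

This account rests on a few compounds, and the source may have more. Where it says the series, first, only, none or still open, it means among the compounds named here.

Compound 1 `Cn1cc(-c2cnc3ccnc(NC(=O)c4ccc(F)cc4)c3c2)cn1` and compound 2 `COc1ccc(C(=O)Nc2nccc3ncc(-c4cnn(C)c4)cc23)cc1` share one core and differ by methoxy in place of fluoro on an aromatic carbon. In a functional assay on HeLa cells (Homo sapiens) for antiproliferative activity, read by MTT assay, with a stated time of 48 h (on this read-out lower numbers stand for stronger inhibition and higher numbers for weaker inhibition), compound 1 gives > 50000 nM, which is a limit of the assay and not a number. In this assay compound 2 gives > 50000 nM, likewise a limit. The step that the two limits leave unreadable from compound 1 to compound 2 therefore cannot be read in size, because of the limit of > 50000 nM in this assay, at which 2 of the 3 values shown sit.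

Compound 3 `Cn1cc(-c2cnc3ccnc(NCc4ccc(F)cc4)c3c2)cn1` sits on a second core; the difference between the two cores is not broken down here. In this assay, among the compounds with values here, compound 3 gives 9200 nM, the only number among the three values obtained so far. Compound 4 `COc1ccc(CNc2nccc3ncc(-c4cnn(C)c4)cc23)cc1` is related to compound 3 by the same change that relates compound 2 to compound 1: methoxy in place of fluoro on an aromatic carbon.

Within the data shown here, since the one measured instance of this change is unreadable, the expected step of a 1.0-fold lower number from compound 3 to compound 4 (0.01 log units; within the scatter) from compound 3 to compound 4 rests on the value of compound 3 in this assay alone, and is estimated as small. Compound 4 is thus expected to give 9000 nM in this assay, with an estimated range from 3000 nM to 30000 nM.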

Compound 4, half-maximal inhibitory concentration: 42200 nM
The estimate for compound 4 lay 4.7-fold (0.67 log units) below the measured number, outside the stated range (above it).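

In this assay, within the data shown here, methoxy in place of fluoro on the core of compound 3 gives a 4.6-fold higher number from compound 3 to compound 4 (0.66 log units; beyond the scatter), which is the one readable instance of this change. On the core of compound 1 the same change cannot be read in size, because compound 1 and compound 2 both give a limit of the assay and not a number: the limit of > 50000 nM in this assay, at which 2 of the 4 values shown sit. This single pair therefore shows a weakening on one core only; it shows neither that the step carries over to the other core nor that it fails to, and it sets no rule for the series.

Still open, as far as these compounds go, is whether an amine or a carboxylic acid in the same place on the aromatic ring would follow the step seen with methoxy. Also open, from the compounds shown here alone, is how a longer chain between that ring and the core of compound 3 would move the number, in either direction.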